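From methyl to phenyl on the saturated chain

A few compounds are considered here, and "the series" means these few. Any claim that something is new, unique, unknown or untested is made for them only; others in the source may bear on it.

For the measured compounds named here, in a functional assay (lung) for inhibition, with Cavia porcellus as the target (a lower number here means a stronger inhibitor, a higher number a weaker inhibitor), compound 1 `CC(CCc1nnn[nH]1)Cc1ccc(OCc2ccc3ccccc3n2)cc1` gives 27 nM as the lowest number so far, which makes it the stronger inhibitor of the two measured. Compound 2 `CC(CCC(=O)O)Cc1ccc(OCc2ccc3ccccc3n2)cc1`, with carboxy in place of 1H-tetrazol-5-yl, gives 100 nM and stands higher. Compound 3 `c1ccc(C(CCc2nnn[nH]2)Cc2ccc(OCc3ccc4ccccc4n3)cc2)cc1` is still unmeasured. It differs from compound 1 by phenyl in place of methyl on a saturated chain carbon bound to two saturated chain carbons, counted as phenyl in place of methyl on a saturated chain carbon bound to two saturated chain carbons in full. Going by the values given here, no measured step touches that place, so the data fix no direction. Among the compounds with values here, the only guide, found at another place in the molecule, is a 3.7-fold higher number from compound 1 to compound 2 (0.57 log units; beyond the scatter) and it offers a sense of scale alone. A modest step is therefore expected in this assay with a slight lean towards a higher number. The expected change is a 2.2-fold higher number from compound 1 to compound 3 (0.35 log units; beyond the scatter) in size. For compound 3 the estimate is 60 nM with an expected range of 12 nM to 300 nM for this measurement.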

Compound 3, half-maximal inhibitory concentration: 14 nM
Estimate against measurement, compound 3: 4.3-fold (0.63 log units) above; the range from low to high includes it.
By their numbers in this assay, from the lowest: compounds 3 and 1 (each within the scatter of the next); then compound 2.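

In this assay, phenyl in place of methyl on a saturated chain carbon bound to two saturated chain carbons gives a 1.9-fold lower number from compound 1 to compound 3 (0.29 log units; within the scatter), so the two compounds cannot be told apart in this assay. For the compounds shown here, this position therefore carries an aromatic ring as well as a methyl group without any loss of inhibition that this measurement can detect, something no earlier pair could show. Nothing available here explains this result.

Going by these compounds, it remains open what a hydrogen, a benzyl group or an amine on this same carbon would do. Going by these compounds alone, it is also open whether swapping 1H-tetrazol-5-yl for carboxy, the one other change seen so far, would have a similar effect in a compound carrying phenyl at this position.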